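The source may report more compounds than this note shows. Statements on the series, on what has been measured and on what is new or still open speak of the compounds shown alone.

Measured so far:
compound 1, `COc1ccc(/C=C/C[C@H]2C[C@@H]([C@@H](O)c3ccccc3)CO[C@@H]2c2ccccc2)cc1`, 9010 nM
compound 2, `COc1ccc(/C=C/C[C@H]2C[C@@H]([C@@H](O)c3ccc(OC)c(OC)c3)CO[C@@H]2c2ccc(OC)c(OC)c2)cc1OC`, 34700 nM

Both numbers come from a functional assay on HL-60 cells (Homo sapiens) for cytotoxicity, read by WST assay, with a stated time of 48 h (on this read-out higher numbers stand for weaker inhibition and lower numbers for stronger inhibition), so the lower of the two marks the stronger inhibitor. Compound 1 holds the lowest number of the pair; compound 2 sits at a higher number, and that gap is wider than the usual scatter of repeated measurements. For the measured compounds named here, only these two compounds have been measured, and they differ in several places at once, so their pair offers no single clean step to lean on.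

The next compound, compound 3, `O[C@@H](c1ccccc1)[C@H]1CO[C@H](c2ccccc2)[C@@H](C/C=C/c2cccnc2)C1`, differs from compound 1 in one place: pyridin-3-yl in place of 4-methoxyphenyl on a double-bonded chain carbon bound to a double-bonded chain carbon. Nothing measured here shows how a swap of this kind plays out in this assay, so the expectation rests on the value of compound 1 alone, with wide room for error.

In this assay the expected step is a 1.3-fold higher number from compound 1 to compound 3 (0.12 log units; within the scatter), a small shift toward a slightly higher number, within or barely beyond the scatter.

Compound 3 is therefore expected to give about 12000 nM in this assay, with a range from 4000 nM to 40000 nM.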

Compound 3, half-maximal inhibitory concentration: > 100000 nM
Compound 3 ended at the assay's limit; the forecaster's own chance of this, stated with the estimate: 10%; middle value at least 8.3-fold (0.92 log units) away from the limit.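

In this assay, pyridin-3-yl in place of 4-methoxyphenyl on a double-bonded chain carbon bound to a double-bonded chain carbon is a costly change (an at least 11-fold higher number from compound 1 to compound 3 (1.04 log units; beyond the scatter)). For the compounds shown here, this is the first single-change comparison, and it shows that this position does not accept just any six-membered aromatic ring: the two groups look alike in outline, yet the inhibition seen with compound 1 is largely or entirely lost in compound 3. The value of compound 3 is a limit of the assay and not a number, so the step gives only a lower bound on the size of the loss: (the limit of > 100000 nM in this assay, at which 1 of the 3 values shown sits).

The change swaps two things at once, removing the methoxy group and putting a nitrogen into the ring, and these compounds cannot tell which of the two matters. On these data alone, it also remains open how a 4-aminophenyl or a pyridin-4-yl group at this same place would behave, and so whether the loss extends to other nitrogen-bearing groups.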